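The source may report more compounds than this note shows. Statements on the series, on what has been measured and on what is new or still open speak of the compounds shown alone.

Measured in a functional assay on HeLa cells (Homo sapiens) for antiproliferative activity, read by MTT assay, with a stated time of 72 h; a higher number here means a weaker inhibitor, a lower number a stronger inhibitor:
Compound 1 `CC/C=C/C(=O)Nc1cccc(Oc2nc(Nc3ccn(C)n3)nc3c2CSCC3)c1`: > 50000 nM (a limit)
Compound 2 `CCC/C=C/C(=O)Nc1cccc(Oc2nc(Nc3ccn(C)n3)nc3c2CSCC3)c1`: 17000 nM

The result of compound 1 is the limit of > 50000 nM in this assay, at which 1 of the 2 values shown sits; it is a limit, not a number. Among the measured compounds shown here, compound 2 at 17000 nM holds the only actual number so far.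

Next is compound 3 `C=C(F)C(=O)Nc1cccc(Oc2nc(Nc3ccn(C)n3)nc3c2CSCC3)c1`, which has 1-fluoroethenyl in place of pent-1-en-1-yl on a carbonyl carbon.

For the measured compounds named here, only one measured step bears on this: an at least 2.9-fold lower number from compound 1 to compound 2 (0.46 log units; beyond the scatter). It is a methyl in place of hydrogen on a saturated chain carbon, and the longer chain went with the lower number. Taken alone, that step would lean towards a higher number for compound 3, but it is a single pair and a far smaller edit than this swap. Going by the values given here, no measured step involves 1-fluoroethenyl, so the direction stays open.

No clear step beyond the scatter is expected in this assay, and the estimated step is a 1.1-fold lower number from compound 2 to compound 3 (0.05 log units; within the scatter). For compound 3 the expected value is 15000 nM, with an estimated range of 3000 nM to 50000 nM.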

Compound 3, half-maximal inhibitory concentration: > 50000 nM
Compound 3: only a limit was reported (the forecaster's own chance of this, stated with the estimate: 25%); middle value at least 3.3-fold (0.52 log units) from the limit.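

In this assay, 1-fluoroethenyl in place of pent-1-en-1-yl on the carbonyl carbon gives an at least 2.9-fold higher number from compound 2 to compound 3 (0.46 log units; beyond the scatter), so this position does not keep a measurable number with every alkenyl-type group, and the 3 heavy atoms of 1-fluoroethenyl do not stand in for the 5 of pent-1-en-1-yl. Of the three groups shown on this carbonyl carbon, only pent-1-en-1-yl gives an actual number, with compound 2 at 17000 nM. The pair of compound 1 and compound 3 gives no readable step, and the order of these two compounds cannot be told, as their results are limits and not numbers: the limit of > 50000 nM in this assay, at which 2 of the 3 values shown sit.

The swap changes chain length and brings in fluorine in one edit, so a plain ethenyl group or a fluorine placed on the pent-1-en-1-yl chain would be needed to tell the two changes apart. From the compounds shown here alone, whether a longer chain such as hex-1-en-1-yl lowers the number further below that of compound 2 also stays open.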